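Removing the side chain from compound 2

A few compounds are considered here, and "the series" means these few. Any claim that something is new, unique, unknown or untested is made for them only; others in the source may bear on it.

Measured so far in a toxicity assay on L02 cells (Homo sapiens) for cytotoxicity, read by MTT assay, with a stated time of 72 h (on this read-out lower numbers stand for stronger inhibition and higher numbers for weaker inhibition), are three compounds.
- Compound 1 `O=C1c2c[n+]([O-])c3ccccc3c2C(=O)c2c1c1ccccc1n2Cc1cn(C[C@H](O)CO)nn1` gives 1130 nM here.
- Compound 2 `O=C1c2c[n+]([O-])c3ccccc3c2C(=O)c2c1c1ccccc1n2CCCCN1CCCCC1` gives 610 nM here.
- Compound 3 `CCCN1CCN(CCCCn2c3c(c4ccccc42)C(=O)c2c[n+]([O-])c4ccccc4c2C3=O)CC1` gives 6830 nM here.

Compound 2 stands at the low end of these numbers, level with compound 1 and well apart from compound 3. The steps of a 1.9-fold lower number from compound 1 to compound 2 (0.27 log units; within the scatter) and an 11-fold higher number from compound 2 to compound 3 (1.05 log units; beyond the scatter) show this.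

Compound 4 `O=C1c2c[n+]([O-])c3ccccc3c2C(=O)c2[nH]c3ccccc3c21` has not yet been measured. Its difference from compound 2 is hydrogen in place of 4-(piperidin-1-yl)butyl on an aromatic nitrogen and, in words, it is hydrogen in place of 4-(piperidin-1-yl)butyl on an aromatic nitrogen.

Among the measured compounds shown here, all three measured compounds carry a chain on that nitrogen, so no measured step removes one. The nearest guide is how far the number moves when one chain replaces another. Together with the two steps above, a 6.0-fold higher number from compound 1 to compound 3 (0.78 log units; beyond the scatter) shows that such swaps range from within the scatter to large. These steps give no clear direction for losing the chain altogether. A modest rise is a tentative expectation, and in this assay the estimated change is a 2.5-fold higher number from compound 2 to compound 4 (0.39 log units; beyond the scatter) with real doubt about its direction. The estimate for compound 4 is 1500 nM with an expected range from 300 nM to 7000 nM as the likely spread.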

Compound 4, half-maximal inhibitory concentration: 400 nM
Beside the measured number, compound 4's estimate is 3.8-fold (0.57 log units) above it; the measured number falls inside the stated range.
By their numbers in this assay, from the lowest: compounds 4, 2 and 1 (each within the scatter of the next, the first and the last beyond it); then compound 3.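

In this assay, among the compounds shown here, the step to the bare aromatic nitrogen is the first measured case with no chain at all on this position, and the reading of a 1.5-fold lower number from compound 2 to compound 4 (0.18 log units; within the scatter) means that the whole 4-(piperidin-1-yl)butyl chain, ring included, can give way to a single hydrogen with no change that stands out from ordinary repeat variation. The chain on compound 1 behaves a little differently, since hydrogen in place of (1-(2,3-dihydroxypropyl)-1H-1,2,3-triazol-4-yl)methyl gives a 2.8-fold lower number from compound 1 to compound 4 (0.45 log units; beyond the scatter) and that shift is real but modest, so the two chains cannot be treated as alike when they are removed. Nothing measured here accounts for either result.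

Still open, on these data alone, is whether a small group on this nitrogen, such as a methyl or a short chain ending in a primary amine, would read like the hydrogen of compound 4 or would move the number further. The compounds shown also leave open how a chain ending in a carboxylic acid would read on this nitrogen in this assay and whether a chain of another length would matter.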